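Hydrogen for hydroxy on compound 1

The source may report more compounds than this note shows. Statements on the series, on what has been measured and on what is new or still open speak of the compounds shown alone.

In a functional assay on MCF7 cells (Homo sapiens) for cytotoxicity, read by MTT assay, with a stated time of 48 h (on this read-out lower numbers stand for stronger inhibition and higher numbers for weaker inhibition), compound 1 (`COc1cc(O)c2c(c1O)C/C(C)=C\[C@@H](O)C[C@@]1(C)O[C@@H]1C2=O`) gives 21000 nM as its half-maximal inhibitory concentration, and compound 2 (`COc1cc(O)c2c(c1O)C[C@]1(C)O[C@@H]1CC[C@@]1(C)O[C@@H]1C2=O`) gives 16100 nM on the same read-out. For the measured compounds named here, these two numbers lie within the scatter of each other, so compound 1 stands level with the only other measured compound, and neither can be ranked above the other. Compound 3 (`COc1cc(O)c2c(c1O)C/C(C)=C\CC[C@@]1(C)O[C@@H]1C2=O`) keeps the core of compound 1 and differs in one place, with hydrogen in place of hydroxy on a saturated ring carbon. Going by the values given here, no measured pair shows this change alone, so the data give no direct guide to its size. Among the compounds with values here, the only available guide is that compound 1 at 21000 nM and compound 2 at 16100 nM sit close together. In this assay no step beyond the scatter is therefore expected, and no direction is favoured. The estimated step of a 1.2-fold lower number from compound 1 to compound 3 (0.07 log units; within the scatter) is accordingly small. For compound 3 the expected value is 18000 nM in this estimate, with an expected range from 7000 nM to 45000 nM as its limits.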

Compound 3, half-maximal inhibitory concentration: 24600 nM
Estimate against measurement, compound 3: 1.4-fold (0.14 log units) below; low and high end bracket the measured number.
By their numbers in this assay, from the lowest: compounds 2, 1 and 3 (each within the scatter of the next).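

In this assay, for the compounds shown here, the step for hydrogen in place of hydroxy on a saturated ring carbon is a 1.2-fold higher number from compound 1 to compound 3 (0.07 log units; within the scatter), which gives the first direct reading of this change, something the earlier compounds could not provide. On the core of compound 1, the read-out therefore does not separate the compound that carries this hydroxy from the one that lacks it, and at this position the hydroxy, with its one hydrogen-bond donor and one hydrogen-bond acceptor, is not shown to be required for the level of cytotoxicity seen here. Nothing at hand gives a reason for this outcome.

The compounds shown leave open whether another group on this ring carbon, such as an amine, a methoxy group or a carboxylic acid, would give a step beyond the scatter, or whether the opposite spatial arrangement of the hydroxy would read differently. They also leave open whether the same exchange would read the same way on a different core or in other cell lines, since this single pair speaks only for one core in one cell line.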